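A few compounds are considered here, and "the series" means these few. Any claim that something is new, unique, unknown or untested is made for them only; others in the source may bear on it.

Measured compounds in an ADME assay on NIH3T3 cells (Mus musculus) for cytotoxicity, read by MTT assay, with a stated time of 24 h; on this read-out lower numbers stand for stronger inhibition and higher numbers for weaker inhibition:
compound 1, `Cn1cnnc1SCCc1nnc(SCC(=O)Nc2nc3ccc(F)cc3s2)o1`: > 500 ug/mL; this value is a limit of the assay, not a number
compound 2, `Cn1cnnc1SCCc1nnc(SCC(=O)Nc2nc3ccccc3s2)o1`: > 500 ug/mL; this value is also a limit, not a number

Compound 2 therefore stands only at the upper limit of this assay, with no number of its own. Within the data shown here, the one measured step, a step that the two limits leave unreadable from compound 1 to compound 2, lies between two limits and cannot be read; the fluoro-to-hydrogen change tells nothing about its size. Both values shown sit at the same limit, (the limit of > 500 ug/mL in this assay, at which 2 of the 2 values shown sit).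

Compound 3, `Cn1cnnc1SCCc1nnc(SCC(=O)Nc2nc3ccc(Cl)cc3s2)o1`, differs from compound 2 by chloro in place of hydrogen on an aromatic carbon. Among the measured compounds shown here, no measured step bears on a chloro group here; the only comparison on this ring, the fluoro-to-hydrogen step, was unreadable. For the step from compound 2 to compound 3 no movement beyond the scatter is expected in this assay; it is estimated as a step that the limit leaves unreadable from compound 2 to compound 3. Compound 3 is expected to sit again at the limit, estimated as 600 ug/mL with a range of 250 ug/mL to 1500 ug/mL.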

Compound 3, half-maximal inhibitory concentration: 422 ug/mL
Beside the measured number, compound 3's estimate is 1.4-fold (0.15 log units) above it; the range from low to high includes it.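

In this assay, among these compounds, compound 3 gives 422 ug/mL, the first reading that is a number and not a limit, so a change on this aromatic carbon can give a compound of this series a number of its own. Chloro in place of hydrogen gives an at least 1.1-fold lower number from compound 2 to compound 3 (0.07 log units; that floor lies within the scatter), and chloro in place of fluoro gives an at least 1.1-fold lower number from compound 1 to compound 3 (0.07 log units; that floor lies within the scatter); neither floor shows a movement beyond the scatter, so a real effect of chloro at this position is not established. The true size of each step stays unknown, with the other end of both steps resting on a limit: the limit of > 500 ug/mL in this assay, at which 2 of the 3 values shown sit.

The compounds shown leave open whether a bromo, methyl or methoxy group on the same aromatic carbon would also give a number in this assay, and whether an amine or a carboxylic acid there would stay at the limit. They also leave open whether the chloro result would hold on another carbon of this ring, or with a longer chain in the shared core.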